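This account rests on a few compounds, and the source may have more. Where it says the series, first, only, none or still open, it means among the compounds named here.

Measured in a functional assay on MDA-MB-231 cells (Homo sapiens) for inhibition, read by sulforhodamine B assay, with a stated time of 48 h; on this read-out higher numbers stand for weaker inhibition of growth and lower numbers for stronger inhibition of growth:
compound 1 `COc1cc(-c2nn(-c3cccc(NC(=O)Nc4ccc(Cl)c(Cl)c4)c3)cc2-c2ccncc2)ccc1Cl`, 1920 nM
compound 2 `COc1cc(-c2nn(-c3cccc(NC(=O)Nc4cccc(C(F)(F)F)c4)c3)cc2-c2ccncc2)ccc1Cl`, 2370 nM
compound 3 `O=C(Nc1cccc(-n2cc(-c3ccncc3)c(-c3ccc(Cl)c(O)c3)n2)c1)Nc1cc(C(F)(F)F)cc(C(F)(F)F)c1`, 1660 nM

Among these three numbers compound 1 stands second highest, with compound 3 nearest and compound 2 furthest, and all three lie within the scatter of one another. Compound 4 `COc1cc(-c2nn(-c3cccc(NC(=O)c4ccccc4)c3)cc2-c2ccncc2)ccc1Cl` differs from compound 1 by phenyl in place of (3,4-dichlorophenyl)amino on a carbonyl carbon. Among the measured compounds shown here, no measured pair shows this kind of change. For the measured compounds named here, the only measured step, a 1.2-fold higher number from compound 1 to compound 2 (0.09 log units; within the scatter), swaps one ring substituent pattern for another while keeping the urea, and changes little. Removing the whole arylamino part of the urea is a larger alteration, so a modest move towards weaker inhibition is expected, though it could also stay within the scatter. The expected step is a 1.8-fold higher number from compound 1 to compound 4 (0.26 log units; within the scatter). Compound 4 is therefore estimated at 3500 nM, in the range 1200 nM to 10000 nM.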

Compound 4, concentration for total growth inhibition: 13700 nM
Compound 4: the middle estimate sits 3.9-fold (0.59 log units) below what was measured, and the stated range ends below it.
By their numbers in this assay, from the lowest: compounds 3, 1 and 2 (each within the scatter of the next); then compound 4.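

The earlier compounds shown here changed only the substituents on the outer ring of the urea, whereas here the amino nitrogen goes as well, and inhibition of growth clearly weakens, with a 7.1-fold higher number from compound 1 to compound 4 (0.85 log units; beyond the scatter) and a 5.8-fold higher number from compound 2 to compound 4 (0.76 log units; beyond the scatter). This place on the carbonyl carbon therefore responds to the loss of the whole arylamino part, in both pairs. Nothing at hand explains this loss of inhibition.

On these data alone, the step removes the nitrogen and the ring substituents together, so their separate shares remain open. A 3,4-dichlorobenzoyl group or an unsubstituted phenylamino group at this place would address that question.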